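Butyl ether of the phenol in a dichlorophenyl lactone series

The source may hold more compounds than are shown below. What is called first, only, known or untested is meant among the compounds shown, and "the series" means these compounds.

The shared core, a lactone bearing two benzylic arms, appears in compound 1 `O=C1OC[C@H](Cc2ccccc2)[C@H]1Cc1ccc(Cl)cc1` and compound 2 `O=C1OC[C@H](Cc2ccccc2)[C@H]1Cc1ccc(Cl)cc1Cl`. In a functional assay on HeLa cells (Homo sapiens) for cytotoxicity, read by WST assay, with a stated time of 48 h (a lower number here means that less compound is needed, a higher number that more compound is needed for the effect), compound 2 gives 23000 nM, whereas compound 1 is recorded as "not determined" (no result reported), with no result reported there. Compound 3 `O=C1OC[C@H](Cc2ccccc2O)[C@H]1Cc1ccc(Cl)c(Cl)c1` likewise stands in this assay as "not determined" (no result reported), so its own level is not known, and the only measured point in the series is compound 2. Compound 4 `CCCCOc1ccccc1C[C@H]1COC(=O)[C@@H]1Cc1ccc(Cl)c(Cl)c1` differs from compound 3 by butyl in place of hydrogen on an oxygen on an aromatic ring. Among the compounds with values here, with no measured pair to anchor the change, the step from compound 3 to compound 4 in this assay is expected to be small, in no firm direction, and compound 4 is estimated at 15000 nM with a range from 4000 nM to 60000 nM.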

Compound 4, half-maximal effective concentration: > 100000 nM
Compound 4 gave a limit, no number (the forecaster's own chance of this, stated with the estimate: 30%); middle value at least 6.6-fold (0.82 log units) away from the limit.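

Within the data shown here, no step from compound 3 to compound 4 can be read: compound 3 has no single number, and compound 4 has only a limit. The compounds shown leave open how far hydroxy to butoxy shifts the effect in this assay.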